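Trimming a methoxy group from the weakest thiophene ketone

The compounds below may be only part of what the source reports. "The series", "measured", "known", "first", "only" and "open" are said of these compounds alone.

Measured so far:
compound 1 `COc1cc(C(=O)c2sc(-c3cccs3)cc2N)cc(OC)c1OC` gives 9.4 nM in a functional assay on CCRF-CEM cells (Homo sapiens) for antiproliferative activity; a higher number here means a weaker inhibitor, a lower number a stronger inhibitor;
compound 2 `COc1cc(C(=O)c2sc(-c3cc(OC)c(OC)c(OC)c3)cc2N)cc(OC)c1OC` gives 840 nM;
compound 3 `COc1cc(C(=O)c2sc(-c3ccc([N+](=O)[O-])cc3)cc2N)cc(OC)c1OC` gives 99 nM.

Among these three, compound 2 stands at the top of the numbers, which here means it is the weakest inhibitor of cell growth: its gap to compound 3 and its larger gap to compound 1 both lie beyond the usual scatter. The three compounds share one core and differ only in the aromatic group attached to it, and that single change moves the numbers a great deal, as the step of an 11-fold higher number from compound 1 to compound 3 (1.02 log units; beyond the scatter) shows.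

Compound 4 `COc1ccc(-c2cc(N)c(C(=O)c3cc(OC)c(OC)c(OC)c3)s2)cc1OC` is compound 2 with one group removed: hydrogen in place of methoxy on an aromatic carbon. The group that leaves sits on the six-membered aromatic ring of carbon only, ortho to a methoxy group and meta to a large group.

For the measured compounds named here, no measured step describes removing a methoxy group from that ring, so the only guidance is indirect: the aromatic group clearly matters, and compound 2 carries the most substituted one. A modest move toward stronger inhibition is therefore expected, close to the edge of the scatter, as the step of a 2.1-fold lower number from compound 2 to compound 4 (0.32 log units; beyond the scatter) expresses. Compound 4 is estimated at 400 nM, within 100 nM to 1500 nM.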

Compound 4, half-maximal inhibitory concentration: 20 nM
The estimate for compound 4 lay 20-fold (1.30 log units) above the measured number; the measured number lies below the stated range.
By their numbers in this assay, from the lowest: compound 1; then compound 4; then compound 3; then compound 2.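

In this assay, taking one methoxy group off the six-membered aromatic ring, at the place ortho to a methoxy group and meta to a large group, gives a 42-fold lower number from compound 2 to compound 4 (1.62 log units; beyond the scatter) as a large step of its own, so a single small group here can change the number a great deal. The 3,4-dimethoxyphenyl group left behind also compares well with the other aromatic groups: a 5.0-fold lower number from compound 3 to compound 4 (0.69 log units; beyond the scatter) is the step from the 4-nitrophenyl group, while a 2.1-fold higher number from compound 1 to compound 4 (0.33 log units; beyond the scatter) shows that it still falls modestly short of the thiophen-2-yl group. The earlier compounds shown here showed only that the choice of aromatic group matters, whereas this pair shows that two methoxy groups on this ring go with a far lower number than three.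

As far as these compounds go, whether a hydroxy or an ethoxy group at this place would behave more like methoxy or more like hydrogen remains open, as does the effect of removing the other methoxy groups from this ring. Nothing available here explains why this one methoxy group makes so large a difference.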